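Swapping nitro for fluoro on a pancreatic-cancer cell assay

A few compounds are considered here, and "the series" means these few. Any claim that something is new, unique, unknown or untested is made for them only; others in the source may bear on it.

Compound 3 `COc1ccc2nc(-c3ccc(N/C=C\C(=O)c4ccc(OC)c([N+](=O)[O-])c4)c(C)c3)sc2c1` and compound 1 `COc1ccc2nc(-c3ccc(N/C=C\C(=O)c4ccc(OC)c(F)c4)c(C)c3)sc2c1` share one core and differ only by fluoro in place of nitro on an aromatic carbon. In a functional assay on MIA PaCa-2 cells (Homo sapiens) for antiproliferative activity, read by sulforhodamine B assay, with a stated time of 48 h (on this read-out higher numbers stand for weaker inhibition and lower numbers for stronger inhibition), compound 3 gives 23600 nM, while compound 1 gives 2300 nM, which is a 10-fold lower number from compound 3 to compound 1 (1.01 log units; beyond the scatter). Compound 2 `COc1ccc(C(=O)/C=C\Nc2ccc(-c3nc4cc(OC)c(OC)c(OC)c4s3)cc2)cc1[N+](=O)[O-]` carries a different core; how the two cores differ is not broken down here. In this assay compound 2 gives 15900 nM, a value that lies within the usual scatter of that of compound 3. Compound 4 `COc1ccc(C(=O)/C=C\Nc2ccc(-c3nc4cc(OC)c(OC)c(OC)c4s3)cc2)cc1F` has not yet been measured and differs from compound 2 by fluoro in place of nitro on an aromatic carbon, the same change seen from compound 3 to compound 1. Because the measured change was a 10-fold lower number from compound 3 to compound 1 (1.01 log units; beyond the scatter), the expected step is an 8.8-fold lower number from compound 2 to compound 4 (0.95 log units; beyond the scatter). For compound 4 the estimated value in this assay is therefore 1800 nM.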

Compound 4, half-maximal inhibitory concentration: 19400 nM
The estimate for compound 4 lay 11-fold (1.03 log units) below the measured number; the whole stated range lies below it.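

In this assay the same swap of nitro for fluoro, made on the other core, gives a 1.2-fold higher number from compound 2 to compound 4 (0.09 log units; within the scatter). Set beside the earlier step, the change does not carry over from one core to the other: the same change on two cores in this assay, a 10-fold lower number (1.01 log units; beyond the scatter) from compound 3 to compound 1 and a 1.2-fold higher number (0.09 log units; within the scatter) from compound 2 to compound 4, 13-fold (1.10 log units) apart, beyond the scatter of two such steps. So the result of this swap cannot be assumed to transfer between these two cores, but this does not show which feature of the cores is responsible, and a single pair on each core gives no rule for the whole series.

The compounds shown leave open how an amine or a chlorine in place of the nitro would behave on each core. From the compounds shown here alone, whether the gap between the two cores would persist with such groups also stays open.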